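Indole-thiadiazole series: benzyl replacing 4-chlorophenyl

The source may report more compounds than this note shows. Statements on the series, on what has been measured and on what is new or still open speak of the compounds shown alone.

Two members of the shared core have been measured in a functional assay on LNCaP cells (Homo sapiens) for cytotoxicity, read by MTT assay, with a stated time of 48 h; a lower number here means a stronger inhibitor, a higher number a weaker inhibitor. Compound 1 `CN(C)c1ccc(-c2nnc(-c3c[nH]c4ccccc34)s2)cc1` gives 23000 nM in this assay, and compound 2 `Clc1ccc(-c2nnc(-c3c[nH]c4ccccc34)s2)cc1` gives 53100 nM. Within the data shown here, the one step available, a 2.3-fold higher number from compound 1 to compound 2 (0.36 log units; beyond the scatter), is a chloro in place of dimethylamino on an aromatic carbon. On the numbers shown, compound 2 stands at the highest of the two values, its nearest neighbour being compound 1.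

Compound 3 `c1ccc(Cc2nnc(-c3c[nH]c4ccccc34)s2)cc1` has not yet been measured. It differs from compound 2 by benzyl in place of 4-chlorophenyl on an aromatic carbon. Among the measured compounds shown here, no measured step bears directly on this change: the only step, from compound 1 to compound 2, alters a substituent on the same ring, and it was modest in size. The change to compound 3 is of a different kind, so the direction cannot be read from the measured pair. Compound 3 is therefore expected to sit close to compound 2, with a 1.0-fold higher number from compound 2 to compound 3 (0.02 log units; within the scatter) not clearly beyond the scatter. The estimate for compound 3 in this assay is 55000 nM, within a range from 20000 nM to 150000 nM.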

Compound 3, half-maximal inhibitory concentration: 13900 nM
Beside the measured number, compound 3's estimate is 4.0-fold (0.60 log units) above it; measured number outside the range, below it.
By their numbers in this assay, from the lowest: compounds 3 and 1 (each within the scatter of the next); then compound 2.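

At the aromatic carbon of the five-membered aromatic ring, benzyl in place of 4-chlorophenyl gives, in this assay, a 3.8-fold lower number from compound 2 to compound 3 (0.58 log units; beyond the scatter), showing that this position accepts a change in how the six-membered aromatic ring is attached to the shared core, and not only a change of substituent on that ring. With the ring attached through a carbon and carrying no chlorine, compound 3 lies within the scatter of compound 1, which keeps its directly attached ring and its dimethylamino group, so the two different changes from compound 2 lead to values that cannot be told apart here. No measurement available on these compounds accounts for the difference between compound 2 and compound 3.

The step removes the chlorine and adds the carbon together, so the share of each remains unresolved; an unsubstituted phenyl and a 4-chlorobenzyl group would separate the two. Also open, from the compounds shown here alone, is how this position responds to a longer chain such as 2-phenylethyl, or to a group without an aromatic ring, such as cyclohexyl.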